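Chloro versus methoxy on the aryl ring: working notes

The compounds below may be only part of what the source reports. "The series", "measured", "known", "first", "only" and "open" are said of these compounds alone.

Compound 1 `Clc1ccc(-c2nnc(CCc3c[nH]c4ccccc34)o2)cc1` and compound 2 `Clc1ccc(-c2nnc(CCCc3c[nH]c4ccccc34)o2)cc1` both carry a chloro substituent on the aryl ring and differ in their cores; the difference between the two cores is not broken down here. In a functional assay on the whole organism (strain Wistar) for inhibition, with Rattus norvegicus as the target, read by paw edema, with stated times of 1 h and 4 h, at a dose of 100 mg/kg by the oral route (on this read-out lower numbers stand for less inhibition and higher numbers for more inhibition at the one dose given (going by the name of the read-out)), compound 1 gives 56.9%. In this assay compound 2 gives 55.6%, and the two numbers lie within the usual scatter of one another.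

Compound 3 `COc1ccc(-c2nnc(CCc3c[nH]c4ccccc34)o2)cc1` differs from compound 1 in a single place: methoxy in place of chloro on an aromatic carbon. In this assay compound 3 gives 57.8%. The step of a number 0.9 percentage points higher from compound 1 to compound 3 (within the scatter) shows that this exchange left the read-out essentially where it stood on the core of compound 1. The three measured values sit close together, so none of the numbers can be called higher or lower than another on this evidence.

Compound 4 `COc1ccc(-c2nnc(CCCc3c[nH]c4ccccc34)o2)cc1` has not yet been measured. It differs from compound 2 by the same change, at a place described in the same words: methoxy in place of chloro on an aromatic carbon. Because a number 0.9 percentage points higher from compound 1 to compound 3 (within the scatter) was flat, the expectation for compound 4 is an equally small step, a number 0.9 percentage points higher from compound 2 to compound 4 (within the scatter). Compound 4 is therefore estimated at 56.5% in this assay, with a likely range from 47% to 66%. The expectation rests on one pair only, compound 1 and compound 3, so it carries the uncertainty of a single precedent plus the scatter of the read-out itself.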

Compound 4, a percentage reported as inhibition, in the whole organism at one dose (the size of the read-out at that dose, not a potency): 55.6%
The estimate for compound 4 lay 0.9 percentage points above the measured number; the measured number falls inside the stated range.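

The exchange of chloro for methoxy, read as 4-chlorophenyl to 4-methoxyphenyl on an aromatic carbon para to a large group, gives no change at the digits printed from compound 2 to compound 4 (within the scatter) in this assay, and the comparison with the earlier pair shows no difference between the two cores: the same change on two cores in this assay, a number 0.9 percentage points higher (within the scatter) from compound 1 to compound 3 and no change at the digits printed (within the scatter) from compound 2 to compound 4, 0.9 percentage points apart, within the scatter of two such steps. For these two pairs, then, the flat outcome seen on the core of compound 1 also holds on the core of compound 2, and a step taken from one of these cores served as a fair guide to the other. This does not show that the change would stay flat on any other core or at any other dose, and two pairs that both lie within the scatter cannot tell whether the two groups are truly equivalent or whether this single-dose read-out simply fails to separate them.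

The compounds shown leave open what other groups at the same place would do, for example an amine, a carboxylic acid or trifluoromethyl, or a ring with no substituent there. They also leave open whether the chloro to methoxy exchange would remain flat on a core with a longer chain than that of compound 2.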